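A few compounds are considered here, and "the series" means these few. Any claim that something is new, unique, unknown or untested is made for them only; others in the source may bear on it.

In a functional assay on HCT-116 cells (Homo sapiens) for antiproliferative activity, read by MTT assay, with a stated time of 72 h (a lower number here means a stronger inhibitor, a higher number a weaker inhibitor), compound 1 `CN(C(=O)CCc1ccccc1)c1ccc2[nH]c(-c3n[nH]c4ccccc34)cc2n1` gives 11200 nM while compound 2 `CN(C(=O)c1ccc(Br)cc1)c1ccc2[nH]c(-c3n[nH]c4ccccc34)cc2n1` gives 6110 nM and compound 3 `CN(C(=O)c1ccc([N+](=O)[O-])cc1)c1ccc2[nH]c(-c3n[nH]c4ccccc34)cc2n1` gives 19900 nM in the same read-out. Compound 2 sits at the low end of the three, level within the scatter with compound 1 and clear only of compound 3. The measured steps are a 1.8-fold lower number from compound 1 to compound 2 (0.26 log units; within the scatter) and a 1.8-fold higher number from compound 1 to compound 3 (0.25 log units; within the scatter) for the swaps on the carbonyl carbon, then a 3.3-fold higher number from compound 2 to compound 3 (0.51 log units; beyond the scatter) for the swap of nitro for bromo on an aromatic carbon. Compound 4 `Cc1ccc(S(=O)(=O)N(C)c2ccc3[nH]c(-c4n[nH]c5ccccc45)cc3n2)cc1` is still unmeasured and differs from compound 2 by (4-methylphenyl)sulfonyl in place of (4-bromophenyl)carbonyl on a nitrogen on an aromatic ring with the shared core unchanged. Among the measured compounds shown here, no measured step replaces a carbonyl with a sulfonyl, so these steps are only loose guides, and the largest of them is modest. The expected step is a 1.6-fold higher number from compound 2 to compound 4 (0.21 log units; within the scatter) in this assay which means a slight lean to a higher number and no shift beyond the scatter. Compound 4 is estimated at 10000 nM with a range of 4000 nM to 25000 nM expected.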

Compound 4, half-maximal inhibitory concentration: 13300 nM
Beside the measured number, compound 4's estimate is 1.3-fold (0.12 log units) below it; the range from low to high includes it.
By their numbers in this assay, from the lowest: compounds 2, 1, 4 and 3 (each within the scatter of the next, the first and the last beyond it).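

In this assay, among the compounds shown here, (4-methylphenyl)sulfonyl in place of (4-bromophenyl)carbonyl on this nitrogen gives a 2.2-fold higher number from compound 2 to compound 4 (0.34 log units; beyond the scatter) as the first step at this position to change the carbonyl link, and it is modest, so the position accepts a sulfonyl with only a limited loss against compound 2. Against the phenethylcarbonyl group, the same sulfonyl gives a 1.2-fold higher number from compound 1 to compound 4 (0.07 log units; within the scatter) and leaves the two compounds level, so the result depends on which carbonyl compound serves as the reference. Nothing available explains either step.

The step from compound 2 changes the link and the ring substituent together, so the share of each remains unresolved. Also open, on these data alone, is how this assay responds to an amine or a carboxylic acid on the phenyl ring of the sulfonyl group.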